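The source may hold more compounds than are shown below. What is called first, only, known or untested is meant among the compounds shown, and "the series" means these compounds.

Working notes on the series in a functional assay on the whole organism for inhibition, with Mythimna separata as the target, with a stated time of 5 days; on this read-out lower numbers stand for an effect already at smaller amounts and higher numbers for an effect only at larger amounts of compound.

Compound 3 `CC(C)(C)n1ncc(OCc2nnc(-c3cc(F)c(F)cc3F)o2)c(Cl)c1=O` gives 75700 nM and stands lowest of the two numbers shown. Compound 1 `CC(C)(C)n1ncc(OCc2nnc(-c3c(F)c(F)c(F)c(F)c3F)o2)c(Cl)c1=O` gives 271000 nM, a higher number than compound 3 beyond the scatter; the two differ in more than one place, so only the two values themselves are compared. Compound 2 `COc1c(F)c(F)cc(-c2nnc(COc3cnn(C(C)(C)C)c(=O)c3Cl)o2)c1F` gives only a limit of the assay in this assay, > 299000 nM. For the measured compounds named here, the one single-point step measured is an at least 3.9-fold lower number from compound 2 to compound 3 (0.59 log units; beyond the scatter), and since compound 2 sits at the limit of > 299000 nM in this assay, at which 1 of the 3 values shown sits, only its minimum size is known.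

Compound 4 `CC(C)(C)n1ncc(OCc2nnc(-c3cc(F)c(F)c(F)c3F)o2)c(Cl)c1=O` differs from compound 3 by fluoro in place of hydrogen on an aromatic carbon, on an aromatic carbon of a six-membered aromatic ring of carbon only, ortho to two fluoro groups and meta to a fluoro group and to a large group. Going by the values given here, no measured step covers fluoro in place of hydrogen on its own. The pair compound 3 and compound 1 suggests that more fluoro on this ring goes with a higher number; with one fluoro added rather than two, a step about midway is expected, a 2.0-fold higher number from compound 3 to compound 4 (0.30 log units; within the scatter). Compound 4 is therefore estimated at 150000 nM, between 60000 nM and 330000 nM.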

Compound 4, half-maximal effective concentration: 240000 nM
Compound 4: the middle estimate sits 1.6-fold (0.20 log units) below what was measured; the measured number falls inside the stated range.
By their numbers in this assay, from the lowest: compound 3; then compounds 4 and 1 (each within the scatter of the next). At a limit, above all of these: compound 2.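

Fluoro in place of hydrogen at this position, ortho to two fluoro groups and meta to a fluoro group and to a large group, now has a measured step of its own in this assay: a 3.2-fold higher number from compound 3 to compound 4 (0.50 log units; beyond the scatter). Hydrogen in place of fluoro on an aromatic carbon gives a 1.1-fold lower number from compound 1 to compound 4 (0.05 log units; within the scatter), so the gap between the printed values of compound 3 and compound 1 is already present with this single fluoro rather than building up with each fluoro added. Fluoro in place of methoxy on an aromatic carbon gives an at least 1.2-fold lower number from compound 2 to compound 4 (0.09 log units; that floor lies within the scatter), and this step cannot be read, since its floor lies within the scatter and compound 2 gives only a limit of the assay: the limit of > 299000 nM in this assay, at which 1 of the 4 values shown sits.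

The compounds shown carry only hydrogen, fluoro and methoxy at this position, so how an amine, a methyl or a chloro group there would read stays open. From the compounds shown here alone, it also stays open whether fluoro at this position gives a step of similar size on an aromatic ring carrying fewer fluoro groups.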